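The compounds below may be only part of what the source reports. "The series", "measured", "known", "first", "only" and "open" are said of these compounds alone.

Measured in an ADME assay (Rattus norvegicus, strain Han-wistar) for pharmacokinetics, at a dose of 1.5 umol/kg by the intravenous route; on this read-out higher numbers stand for wider distribution into tissues and lower numbers for narrower distribution:
- Compound 1 `COc1cc(F)ccc1-c1ccnc2[nH]c(C3CCN(CC(=O)N(C)C)CC3)cc12`: 2.3 L/kg
- Compound 2 `CC(C)n1nc(-c2ccnc3[nH]c(C4CCN(CC(=O)N(C)C)CC4)cc23)ccc1=O`: 2.9 L/kg

Compound 2, at 2.9 L/kg, lies within the scatter of compound 1. Compound 3 `CC(C)n1cc(-c2ccnc3[nH]c(C4CCN(CC(=O)N(C)C)CC4)cc23)cnc1=O` has not yet been measured. It has the same atoms as compound 2, joined differently: a group of 10 heavy atoms (7 carbon, 2 nitrogen, 1 oxygen; one six-membered aromatic ring with 2 hetero atoms) in place of a group of 10 heavy atoms (7 carbon, 2 nitrogen, 1 oxygen; one six-membered aromatic ring with 2 hetero atoms), on an aromatic carbon. Among the measured compounds shown here, only one measured step bears on this change, a 1.3-fold higher number from compound 1 to compound 2 (0.10 log units; within the scatter), where one aromatic ring group also replaced another on the same carbon. That step gives no reason to expect a real shift in this assay. The expected change is a 1.0-fold lower number from compound 2 to compound 3 (0.02 log units; within the scatter), nothing beyond the scatter. Compound 3 is estimated at 2.8 L/kg, within a range of 1.5 L/kg to 5.2 L/kg.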

Compound 3, volume of distribution in the Rattus norvegicus assay: 2.9 L/kg
The estimate for compound 3 lay 1.0-fold (0.02 log units) below the measured number; measured number inside the range.
By their numbers in the Rattus norvegicus assay, from the lowest: compounds 1, 2 and 3 (each within the scatter of the next).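

In the Rattus norvegicus assay, exchanging one ring arrangement for the other on this aromatic carbon gives no change at the digits printed from compound 2 to compound 3 (within the scatter), and the ring with two hetero atoms in place of the carbon-only ring gives a 1.3-fold higher number from compound 1 to compound 3 (0.10 log units; within the scatter). The earlier compounds shown here could not show that two rings with the same atoms, joined differently, can stay within the scatter for tissue distribution yet differ widely in a physicochemical assay for lipophilicity, using the shake flask method, measured as octanol-water partition, at pH 7.4; on this read-out higher numbers stand for higher lipophilicity and lower numbers for lower lipophilicity: the measured distribution coefficient of compound 2, 2, and of compound 3, 0.4, a number 1.60 log units lower (beyond the scatter) In the physicochemical assay compound 2 gives 2 and compound 3 gives 0.4.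

As far as these compounds go, whether an amine or a carboxylic acid on this ring would move the volume of distribution beyond the scatter remains open.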